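This account rests on a few compounds, and the source may have more. Where it says the series, first, only, none or still open, it means among the compounds named here.

Measured so far in an ADME assay on BHK-21 cells (Mesocricetus auratus) for cytotoxicity, read by MTT assay, with a stated time of 96 h; on this read-out lower numbers stand for higher toxicity in this test and higher numbers for lower toxicity in this test:
- compound 1, `CN(C)CCCNc1ccc(/N=N/c2ccccc2)cc1`: 31000 nM
- compound 2, `O=[N+]([O-])c1cccc(/N=N/N2CCCC2)c1`: 42000 nM
- compound 3, `c1ccc(/N=N/N2CCCC2)cc1`: >= 100000 nM

Notes. The value of compound 3 in this assay is a limit of the assay, not a number. Among the measured compounds shown here, compound 1 and compound 2 give numbers that lie within the usual scatter of each other, and no counted step between them is given here.

One step is measured within the series: from compound 3 to compound 2, the change is nitro in place of hydrogen on an aromatic carbon, and it gives an at least 2.3-fold lower number from compound 3 to compound 2 (0.37 log units; beyond the scatter). That the step is given as an at-least figure follows because compound 3 sits at the limit of >= 100000 nM in this assay, at which 1 of the 3 values shown sits.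

Compound 4, `CN(C)CCCNc1ccc(/N=N/c2ccc([N+](=O)[O-])cc2)cc1`, is not yet measured. Relative to compound 1 it carries nitro in place of hydrogen on an aromatic carbon. For the measured compounds named here, this is the same kind of change as the one from compound 3 to compound 2, but not the same: in compound 4 the nitro sits para to a large group, whereas in compound 2 it sits meta to a group of 7 heavy atoms. How the core of compound 1 differs from the core of compound 3 is not broken down here.

Expectation. Going by the values given here, the one measured instance of this kind of change, an at least 2.3-fold lower number from compound 3 to compound 2 (0.37 log units; beyond the scatter), lowered the number by at least a modest amount. Placing that step beside compound 1 at 31000 nM, compound 4 is expected to move by a 2.1-fold lower number from compound 1 to compound 4 (0.32 log units; beyond the scatter) in this assay. Among the compounds with values here, the estimate for compound 4 is 15000 nM, with a range from 6000 nM to 40000 nM, resting on the single measured step and on the differing surroundings of the nitro group.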

Compound 4, half-maximal cytotoxic concentration: > 100000 nM
Compound 4: a limit, no number (the forecaster's own chance of this, stated with the estimate: 5%); middle value at least 6.6-fold (0.82 log units) from the limit.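

On the core of compound 1, nitro in place of hydrogen on an aromatic carbon gives an at least 3.2-fold higher number from compound 1 to compound 4 (0.50 log units; beyond the scatter) in this assay, so the lower number seen on the other core does not carry over to this one, and the same change runs in opposite directions on the two cores: the same change on two cores in this assay, an at least 2.3-fold lower number (0.37 log units; beyond the scatter) from compound 3 to compound 2 and an at least 3.2-fold higher number (0.50 log units; beyond the scatter) from compound 1 to compound 4, at least 7.6-fold (0.88 log units) apart, beyond the scatter of two such steps

In this assay, on these data alone, compound 4 gives > 100000 nM, which is a limit of the assay and not a number, so the true size of the step on this core remains unknown, and the reversal is the firm finding rather than its magnitude. The two steps do not separate the effect of the core from that of the place of the nitro group, which in compound 4 is para to a large group, and they give no cause for the reversal.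

The compounds shown leave open whether the reversal is particular to nitro or also appears with another group at the same place, such as an amine or a carboxylic acid, on both cores. Also open, as far as these compounds go, is how the number in this assay responds to a longer chain on the core of compound 1, with and without the nitro group.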